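The compounds below may be only part of what the source reports. "The series", "measured", "known", "first", "only" and "open" are said of these compounds alone.

Compound 1 `O=C1CSC(c2cccc(Cl)c2)N1CCN1CCCCC1`: 77%
Compound 2 `O=C1CSC(c2cccc(F)c2)N1CCN1CCCCC1`: 84%

For the measured compounds named here, in an ADME assay on Vero cells (Chlorocebus sabaeus) for cytotoxicity, read by neutral red uptake, tested at 197 ug/mL (a higher number here means a weaker effect of the compound at the concentration tested, a lower number a stronger effect), compound 2 gives 84%, and its only neighbour is compound 1 with 77%; the step of a number 7 percentage points higher from compound 1 to compound 2 (within the scatter) is within the scatter, so the two compounds are not told apart. Compound 3 `COc1cccc(C2SCC(=O)N2CCN2CCCCC2)c1` differs from compound 2 by methoxy in place of fluoro on an aromatic carbon. Going by the values given here, the single measured step concerned fluoro in place of chloro, not methoxy in place of fluoro, and was within the scatter, so no measured step bears directly on this change. Compound 3 is therefore expected to give 82%, with a range from 65% to 96%. For compound 3 the expected step is a number 2 percentage points lower from compound 2 to compound 3 (within the scatter), not beyond the scatter.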

Compound 3, a percentage reported as activity, at one concentration (the size of the read-out at that concentration, not a potency): 66%
Compound 3: the middle estimate sits 16 percentage points above what was measured; the measured number falls inside the stated range.
By their numbers in this assay, from the lowest: compound 3; then compounds 1 and 2 (each within the scatter of the next).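

In this assay, this position on the aromatic ring now shows a change beyond the scatter: methoxy in place of fluoro gives a number 18 percentage points lower from compound 2 to compound 3 (beyond the scatter), and methoxy in place of chloro gives a number 11 percentage points lower from compound 1 to compound 3 (beyond the scatter), both modest. Fluoro and chloro could not be told apart here, so methoxy is the first group at this position to separate from both. Nothing measured on these compounds explains this difference.

As far as these compounds go, whether an amine, a hydroxyl or a longer ether such as ethoxy at this position would give a number like that of methoxy stays open.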